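Shifting the fluorine on the phenyl group of compound 2

The source may hold more compounds than are shown below. What is called first, only, known or untested is meant among the compounds shown, and "the series" means these compounds.

compound 1 `Cc1cnc(Nc2ccc([N+](=O)[O-])cc2)nc1Nc1nc2ccccc2s1` — 6330 nM
compound 2 `Cc1cnc(Nc2ccc(F)cc2)nc1Nc1nc2ccccc2s1` — > 50000 nM (a limit of the assay)

In a functional assay on HCT-116 cells (Homo sapiens) for antiproliferative activity, read by MTT assay, with a stated time of 48 h (on this read-out higher numbers stand for weaker inhibition and lower numbers for stronger inhibition), compound 1 gives 6330 nM. Compound 2 reaches only the limit of the assay in this assay, > 50000 nM, so where it stands on the numbers shown is known only as a bound (the limit of > 50000 nM in this assay, at which 1 of the 2 values shown sits). Among the compounds with values here, the single measured step is an at least 7.8-fold higher number from compound 1 to compound 2 (0.89 log units; beyond the scatter), a weakening that is at least modest.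

Compound 3 `Cc1cnc(Nc2cccc(F)c2)nc1Nc1nc2ccccc2s1` differs from compound 2 by the change (3-fluorophenyl in place of 4-fluorophenyl on a nitrogen on an aromatic ring). Within the data shown here, no measured step touches the position of the fluorine on the phenyl group, so nothing speaks directly to this move. Among the measured compounds shown here, the only guidance is that the fluorophenyl compound 2 already sits at the limit, and the shift to 3-fluorophenyl is not expected to pull compound 3 back toward the range of compound 1. For compound 3 the step that the limit leaves unreadable from compound 2 to compound 3 is therefore expected to be none beyond the scatter. Compound 3 is estimated at 60000 nM in this assay, in the range 15000 nM to 200000 nM, with a high chance that only a limit is returned.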

Compound 3, half-maximal inhibitory concentration: 27800 nM
For compound 3 the middle estimate is 2.2-fold (0.33 log units) above the measured one; the range from low to high includes it.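

In this assay compound 3 returns a real number, so this position can carry a fluorophenyl group without the reading sitting at a limit. The move of the fluorine from 4-fluorophenyl to 3-fluorophenyl gives an at least 1.7-fold lower number from compound 2 to compound 3 (0.25 log units; that floor lies within the scatter), and its true size is known only as a floor: the limit of > 50000 nM in this assay, at which 1 of the 3 values shown sits. Against the nitro compound, the 3-fluorophenyl group still gives a 4.4-fold higher number from compound 1 to compound 3 (0.64 log units; beyond the scatter), so 4-nitrophenyl keeps a modest edge on this nitrogen even over the fluorophenyl group that can be read.

The compounds shown leave open whether the place of a substituent on this phenyl group matters for groups other than fluorine, nitro included. As far as these compounds go, how a methoxy group, an amine or a carboxylic acid on the same phenyl group would compare with nitro and fluoro also stays open.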